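Estimating compound 4 from one methoxy step

A few compounds are considered here, and "the series" means these few. Any claim that something is new, unique, unknown or untested is made for them only; others in the source may bear on it.

Going by the values given here, in a functional assay on PC-3 cells (Homo sapiens) for cytotoxicity, read by MTT assay, with a stated time of 48 h (a lower number here means a stronger inhibitor, a higher number a weaker inhibitor), compound 1 (`O=C(O)CN1C(=O)/C(=C/c2nc3ccccc3n2Cc2ccccc2F)SC1=S`) gives 1860 nM as the lowest of the three numbers so far, which makes it the strongest inhibitor measured. Compound 2 (`O=C(O)CN1C(=O)/C(=C/c2nc3ccccc3n2Cc2ccc(F)c(F)c2)SC1=S`) gives 5970 nM with 3,4-difluorophenyl in place of 2-fluorophenyl, a modest change that shows a 3.2-fold higher number from compound 1 to compound 2 (0.51 log units; beyond the scatter) in a different part of the molecule. Compound 3 (`COc1ccc2c(c1)nc(/C=C1\SC(=S)N(CC(=O)O)C1=O)n2Cc1ccccc1F`) gives 24700 nM with methoxy in place of hydrogen on an aromatic carbon, and this large change shows a 13-fold higher number from compound 1 to compound 3 (1.12 log units; beyond the scatter) for that swap.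

Compound 4 (`COc1ccc2nc(/C=C3\SC(=S)N(CC(=O)O)C3=O)n(Cc3ccccc3F)c2c1`) has not yet been measured. Among the compounds with values here, its difference from compound 1 (methoxy in place of hydrogen on an aromatic carbon) is also methoxy in place of hydrogen on an aromatic carbon, but on a different carbon from the one used in compound 3. The methoxy example of compound 3 at 24700 nM is therefore the closest guide, while the step in compound 2 bears on it only loosely. A single example cannot show how much the choice of carbon matters, so a higher number is expected, though perhaps not as high. The estimated change is a 5.4-fold higher number from compound 1 to compound 4 (0.73 log units; beyond the scatter) on this reasoning. The estimate for compound 4 is 10000 nM and it is expected to fall from 2800 nM to 35000 nM when measured.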

Compound 4, half-maximal inhibitory concentration: > 50000 nM
Compound 4 gave a limit, no number (the forecaster's own chance of this, stated with the estimate: 8%); middle value at least 5.0-fold (0.69 log units) away from the limit.
By their numbers in this assay, from the lowest: compound 1; then compound 2; then compound 3. At a limit, above all of these: compound 4.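

In this assay compound 4 gives a limit and not a number: the limit of > 50000 nM in this assay, at which 1 of the 4 values shown sits.

Even so, the step can be read in one direction, and methoxy on this second aromatic carbon brings an at least 26-fold higher number from compound 1 to compound 4 (1.42 log units; beyond the scatter). Compound 3, with methoxy on the other carbon, gives 24700 nM, so on both carbons shown the same swap moves the number up from that of compound 1, and neither methoxy compound goes against this, something the single earlier example could not show.

From the compounds shown here alone, the true size of the step for compound 4 stays unknown, as does whether this rise belongs to methoxy in particular or would follow any group placed on these aromatic carbons. A hydroxyl or a chlorine on the same carbons, or an ethoxy as a longer chain, would help to separate these possibilities, and each could be tested with the 2-fluorophenyl part of compound 1 kept unchanged.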